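Aryl exchange from compound 2 to compound 3

The compounds below may be only part of what the source reports. "The series", "measured", "known", "first", "only" and "open" are said of these compounds alone.

In a functional assay on U-251 cells (Homo sapiens) for antiproliferative activity, read by MTT assay, with a stated time of 72 h (a lower number here means a stronger inhibitor, a higher number a weaker inhibitor), compound 1 (`O=C1C=C(N2CCC(c3ccccc3)CC2)C(=O)c2c(O)cccc21`) gives 10800 nM and compound 2 (`O=C1C=C(N2CCC(c3ccc(Cl)cc3)CC2)C(=O)c2c(O)cccc21`) gives 6100 nM, so these two values lie within the scatter of each other. Compound 3 (`Cc1ccccc1C1CCN(C2=CC(=O)c3cccc(O)c3C2=O)CC1`) has 2-methylphenyl in place of 4-chlorophenyl on a saturated ring carbon. For the measured compounds named here, the only measured step, a 1.8-fold lower number from compound 1 to compound 2 (0.25 log units; within the scatter), is chloro in place of hydrogen on an aromatic carbon. Going by the values given here, no step for a methyl group has been measured, so this assay is expected to show no step beyond the scatter. The expected change is a 1.3-fold higher number from compound 2 to compound 3 (0.12 log units; within the scatter) and stays within the scatter. For compound 3 the estimated value is 8000 nM with an expected range (3500 nM to 18000 nM).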

Compound 3, half-maximal inhibitory concentration: 30400 nM
For compound 3 the middle estimate is 3.8-fold (0.58 log units) below the measured one; measured number outside the range, above it.
By their numbers in this assay, from the lowest: compounds 2 and 1 (each within the scatter of the next); then compound 3.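

In this assay, the aryl group on this saturated ring carbon now yields a change beyond the scatter: 2-methylphenyl in place of 4-chlorophenyl gives a 5.0-fold higher number from compound 2 to compound 3 (0.70 log units; beyond the scatter). The added methyl group alone gives a 2.8-fold higher number from compound 1 to compound 3 (0.45 log units; beyond the scatter), whereas the chloro step stayed within the scatter. No measured evidence accounts for this rise.

The compounds shown leave open whether the rise follows the methyl group itself or its place on the aryl ring, which 4-methylphenyl would test. Also open, from the compounds shown here alone, is how a methoxy group or an amine on that aryl ring would read here.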